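This account rests on a few compounds, and the source may have more. Where it says the series, first, only, none or still open, it means among the compounds named here.

Compound 2 `CC(=O)Nc1c(C)c(C(OC(C)(C)C)C(=O)O)c(-c2ccc(C)c(C)c2)c(C)c1-c1ccc(C)c(C)c1` gives 19000 nM in an ADME assay on MT4 cells (Homo sapiens) for cytotoxicity, read by MTT assay, with a stated time of 4 days; on this read-out higher numbers stand for lower toxicity in this test and lower numbers for higher toxicity in this test. Compound 1 `Cc1ccc(-c2c(C)c(-c3ccc4c(c3C)CCCO4)c(C(OC(C)(C)C)C(=O)O)c(C)c2NS(C)(=O)=O)cc1C` gives 24000 nM and compound 3 `Cc1ccc(-c2c(C)c(-c3ccc(Cl)c(F)c3)c(C(OC(C)(C)C)C(=O)O)c(C)c2NS(C)(=O)=O)cc1C` gives 22000 nM; both of these numbers lie within the scatter of the number for compound 2, so the three are not separated by this assay. Compound 4 `Cc1ccc(-c2c(C)c(-c3ccc(C)c(C)c3)c(C(OC(C)(C)C)C(=O)O)c(C)c2NC(=O)Nc2ccccc2)cc1C` differs from compound 2 by anilino in place of methyl on a carbonyl carbon. For the measured compounds named here, the only measured single-point step, a 1.1-fold lower number from compound 1 to compound 3 (0.04 log units; within the scatter), alters a different part of the shared core, and no measured step alters the group on the amide-type nitrogen. Since nothing in this set moves beyond the scatter, the change is expected to give a step within the scatter as well, a 1.1-fold higher number from compound 2 to compound 4 (0.02 log units; within the scatter). Compound 4 is therefore estimated at 20000 nM, within 8000 nM to 45000 nM.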

Compound 4, half-maximal cytotoxic concentration: 8000 nM
Compound 4: the middle estimate sits 2.5-fold (0.40 log units) above what was measured; the range from low to high includes it.
By their numbers in this assay, from the lowest: compound 4; then compounds 2, 3 and 1 (each within the scatter of the next).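

In this assay, for the compounds shown here, anilino in place of methyl on a carbonyl carbon gives a 2.4-fold lower number from compound 2 to compound 4 (0.38 log units; beyond the scatter) and is the first step in this set beyond the scatter. Going by these compounds alone, this place on the shared core therefore does affect the read-out, here modestly and towards higher toxicity in this test, whereas the earlier compounds stayed within the scatter of one another. No measurement shown explains the step. Still open, as far as these compounds go, is whether the aromatic ring or the added nitrogen matters: a phenyl or a methylamino on this carbonyl carbon would separate the two.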